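This account rests on a few compounds, and the source may have more. Where it says the series, first, only, none or still open, it means among the compounds named here.

Measured compounds:

Compound 1 `CC(C)(C)Cc1csc(N)c1C(=O)c1ccc(Cl)cc1` gives 1% in an assay on CHO cells for displacement of a labelled ligand from adenosine receptor A1 (Homo sapiens), read by scintillation counting, tested at 10 uM; a lower number here means less inhibition, a higher number more inhibition at the concentration tested (going by the name of the read-out).
Compound 2 `CC(C)(C)Cc1c(-c2ccc(F)cc2F)sc(N)c1C(=O)c1ccc(Cl)cc1` gives 1% in this assay.
Compound 3 `CC(C)(C)Cc1c(Br)sc(N)c1C(=O)c1ccc(Cl)cc1` gives 1% in this assay.

Compound 3 stands level with compounds 1 and 2 at the digits shown; every difference among the three lies within the scatter. Compound 4 `COc1ccc(-c2sc(N)c(C(=O)c3ccc(Cl)cc3)c2CC(C)(C)C)cc1` differs from compound 3 in one place: 4-methoxyphenyl in place of bromo on an aromatic carbon. For the measured compounds named here, the steps that bear on this change all alter the same aromatic carbon: no change at the digits printed from compound 1 to compound 2 (within the scatter), no change at the digits printed from compound 1 to compound 3 (within the scatter) and no change at the digits printed from compound 2 to compound 3 (within the scatter). None of them moved the read-out beyond the scatter, whether a hydrogen, a bromo or a 2,4-difluorophenyl sat there. The step for compound 4 is therefore expected to be small, a number 1 percentage points higher from compound 3 to compound 4 (within the scatter), with no direction beyond the scatter. Compound 4 is estimated at 2%, in the range 0% to 12%.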

Compound 4, a percentage reported as inhibition, at one concentration (the size of the read-out at that concentration, not a potency): 1%
Beside the measured number, compound 4's estimate is 1 percentage points above it; the measured number falls inside the stated range.
By their numbers in this assay, from the lowest: compounds 1, 2, 3 and 4 (each within the scatter of the next).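

For the compounds shown here, replacing bromo with 4-methoxyphenyl, the first group at this aromatic carbon to bring an oxygen and a hydrogen-bond acceptor, leaves the read-out in this assay unmoved (no change at the digits printed from compound 3 to compound 4 (within the scatter)). The comparisons with 2,4-difluorophenyl (no change at the digits printed from compound 2 to compound 4 (within the scatter)) and with hydrogen (no change at the digits printed from compound 1 to compound 4 (within the scatter)) agree, so the flat picture at this position now extends to a ring with an oxygen on it. Nothing available explains this flat result.

Going by these compounds, whether an amine or a carboxylic acid at this carbon would lift the read-out remains open. So does the effect of a longer chain in place of the neopentyl group.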